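From triazole to carboxy on the side chain

This account rests on a few compounds, and the source may have more. Where it says the series, first, only, none or still open, it means among the compounds named here.

Measured in a functional assay on HCT-116 cells (Homo sapiens) for antiproliferative activity, read by sulforhodamine B assay, with a stated time of 72 h; a higher number here means a weaker inhibitor, a lower number a stronger inhibitor:
Compound 1 `Cn1ncc(Cl)c1-c1cc(C(=O)N[C@@H]2CN[C@H](CCN3CCC(O)CC3)C[C@H]2c2ccc(Cl)c(Cl)c2)oc1Cl`: 13700 nM
Compound 2 `Cn1ncc(Cl)c1-c1cc(C(=O)N[C@@H]2CN[C@H](CCCO)C[C@H]2c2ccc(Cl)c(Cl)c2)oc1Cl`: 510 nM
Compound 3 `Cn1ncc(Cl)c1-c1cc(C(=O)N[C@@H]2CN[C@H](CCn3cncn3)C[C@H]2c2ccc(Cl)c(Cl)c2)oc1Cl`: 560 nM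

Compound 3 stands level with compound 2 (a 1.1-fold higher number from compound 2 to compound 3 (0.04 log units; within the scatter)) and far from compound 1 (a 24-fold lower number from compound 1 to compound 3 (1.39 log units; beyond the scatter)). Compound 4 `Cn1ncc(Cl)c1-c1cc(C(=O)N[C@@H]2CN[C@H](CC(=O)O)C[C@H]2c2ccc(Cl)c(Cl)c2)oc1Cl` has carboxy in place of (1H-1,2,4-triazol-1-yl)methyl on a saturated chain carbon bound to a saturated ring carbon. Only changes at this chain bear on it. They can be large (a 27-fold lower number from compound 1 to compound 2 (1.43 log units; beyond the scatter)) or lie within the scatter (a 1.1-fold higher number from compound 2 to compound 3 (0.04 log units; within the scatter)). Within the data shown here, no measured compound carries carboxy, so this is a judgement with wide uncertainty. A large step towards a higher number is expected (an 11-fold higher number from compound 3 to compound 4 (1.03 log units; beyond the scatter)). In this assay compound 4 is estimated at 6000 nM (range 1200 nM to 30000 nM).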

Compound 4, half-maximal inhibitory concentration: 4020 nM
The estimate for compound 4 lay 1.5-fold (0.17 log units) above the measured number; low and high end bracket the measured number.
By their numbers in this assay, from the lowest: compounds 2 and 3 (each within the scatter of the next); then compound 4; then compound 1.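

Until now, changes at this chain had either left the number level or raised it sharply. Carboxy gives an intermediate result: it stands clearly apart from both the 1H-1,2,4-triazol-1-yl group (a 7.2-fold higher number from compound 3 to compound 4 (0.86 log units; beyond the scatter)) and the hydroxyl-ended chain of compound 2 (a 7.9-fold higher number from compound 2 to compound 4 (0.90 log units; beyond the scatter)). It also stays clear of the 4-hydroxypiperidin-1-yl group (a 3.4-fold lower number from compound 1 to compound 4 (0.53 log units; beyond the scatter)).

On these data alone, whether a methyl ester in place of carboxy, or a longer chain ending in carboxy, would recover the lower numbers remains open. No measured evidence explains these steps.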